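The source may hold more compounds than are shown below. What is called first, only, known or untested is meant among the compounds shown, and "the series" means these compounds.

Measured so far in a functional assay (Cavia porcellus) with sulfonylurea receptors; K-ATP channels (Homo sapiens) as the target; a higher number here means a weaker inhibitor, a lower number a stronger inhibitor:
compound 1, `CC(O)(C(=O)Nc1ccc(S(=O)(=O)c2ccccc2O)cc1)C(F)(F)F`: 3090 nM
compound 2, `CC(O)(C(=O)Nc1ccc(S(=O)(=O)c2ccccc2)c(C(F)(F)F)c1)C(F)(F)F`: > 30000 nM, which is a limit of the assay and not a number
compound 3, `CC(O)(C(=O)Nc1ccc(C(=O)c2ccccc2)c(O)c1)C(F)(F)F`: 4200 nM

Compound 1 holds the lower of the two numbers obtained in this assay. Its nearest neighbour is compound 3, whose value lies within the usual scatter of that of compound 1, so no order between the two is claimed. Compound 2 sits at the limit of > 30000 nM in this assay, at which 1 of the 3 values shown sits.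

Compound 4, `CC(O)(C(=O)Nc1ccc(S(=O)(=O)c2nccs2)cc1)C(F)(F)F`, has not yet been measured. Against compound 1 the change is 1,3-thiazol-2-yl in place of 2-hydroxyphenyl on a sulfonyl sulfur. Among the compounds with values here, no measured pair covers this change; compound 2 and compound 3 differ from compound 1 in other places and give no direct guide to it. The step from compound 1 to compound 4 is expected to be a moderate loss, a 2.3-fold higher number from compound 1 to compound 4 (0.36 log units; beyond the scatter), larger than the scatter but well short of the assay limit. Compound 4 is therefore estimated at 7000 nM in this assay, with a range of 2500 nM to 20000 nM.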

Compound 4, half-maximal inhibitory concentration: 1400 nM
For compound 4 the middle estimate is 5.0-fold (0.70 log units) above the measured one; measured number outside the range, below it.
By their numbers in this assay, from the lowest: compound 4; then compounds 1 and 3 (each within the scatter of the next). At a limit, above all of these: compound 2.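

In this assay, the sulfonyl sulfur accepts a change of its aromatic group without loss: 1,3-thiazol-2-yl in place of 2-hydroxyphenyl gives a 2.2-fold lower number from compound 1 to compound 4 (0.34 log units; beyond the scatter). The 2-hydroxyphenyl group is therefore not required for a number in this range, since the entering group has 5 heavy atoms, one five-membered aromatic ring with 2 hetero atoms and 0 hydrogen-bond donors. No measured property shown here bears on the direction of this step.

The compounds shown leave open whether the step follows from the ring nitrogen and sulfur that enter or from the hydroxyl that leaves; a plain phenyl on the sulfonyl sulfur of the core of compound 1 would separate the two. Also open, on these data alone, is how an amine or a carboxylic acid on the 1,3-thiazol-2-yl ring would read.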